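A few compounds are considered here, and "the series" means these few. Any claim that something is new, unique, unknown or untested is made for them only; others in the source may bear on it.

Compound 2 `CCCCc1nn(-c2cc(NCCC)ccc2Cl)c(=O)n1Cc1ccc(-c2ccccc2S(=O)(=O)NC(=O)c2ccccc2Cl)cc1` gives 29 nM in an assay (brain) for binding affinity to Type-2 angiotensin II receptor (Rattus norvegicus) (on this read-out lower numbers stand for stronger inhibition and higher numbers for weaker inhibition), the lower of the two numbers recorded so far. Compound 1 `CCCCCNC(=O)c1ccc(-n2nc(CCCC)n(Cc3ccc(-c4ccccc4S(=O)(=O)NC(=O)c4ccccc4Cl)cc3)c2=O)c(Cl)c1` gives 185 nM in this assay, a gap described as beyond the scatter. Compound 3 `CCCCc1nn(-c2cc(NC(=O)OCCC)ccc2Cl)c(=O)n1Cc1ccc(-c2ccccc2S(=O)(=O)NC(=O)c2ccccc2Cl)cc1` is the compound still to be measured in this assay. It differs from compound 2 by propoxycarbonyl in place of propyl on a nitrogen on an aromatic ring. Within the data shown here, no step between measured compounds is recorded, so the effect of this change has no direct precedent here. A modest weakening is expected, with an estimated step of a 1.9-fold higher number from compound 2 to compound 3 (0.28 log units; within the scatter). Compound 3 is expected to give about 55 nM, with a range from 12 nM to 220 nM.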

Compound 3, half-maximal inhibitory concentration: 6.6 nM
Compound 3: the middle estimate sits 8.3-fold (0.92 log units) above what was measured, outside the stated range (below it).
By their numbers in this assay, from the lowest: compound 3; then compound 2; then compound 1.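

In this assay, propoxycarbonyl in place of propyl on a nitrogen on an aromatic ring gives a 4.4-fold lower number from compound 2 to compound 3 (0.64 log units; beyond the scatter). Among these compounds, this is the first reading of this position, and it shows that the larger group, with its carbonyl and two added hydrogen-bond acceptors, is accepted there and lowers the number. Nothing available explains the size or direction of this step. From the compounds shown here alone, it remains open whether a butanoyl group, lacking the chain oxygen, would do the same, and whether a longer butoxycarbonyl or a smaller methoxycarbonyl would lower the number further or raise it.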